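Methoxy in place of methyl on compound 3

A few compounds are considered here, and "the series" means these few. Any claim that something is new, unique, unknown or untested is made for them only; others in the source may bear on it.

In an ADME assay on Caco-2 cells (Homo sapiens) for permeability, read by LC-MS, with a stated time of 2 h (on this read-out lower numbers stand for lower permeability and higher numbers for higher permeability), compound 1 `Cc1cc(CN(CC2CC2)C(CC(=O)O)c2ccc(Cl)cc2)ccc1OCCN1C(=O)CCC1=O` gives 5.2 nm/s and compound 2 `CCCN(Cc1ccc(OCCn2c(=O)ccn(C)c2=O)c(C)c1)C(CC(=O)O)c1ccc(Cl)cc1` gives 3.2 nm/s while compound 3 `Cc1cc(CN(CC2CC2)C(CC(=O)O)c2ccc(Cl)cc2)ccc1OCCn1c(=O)ccn(C)c1=O` gives 3.7 nm/s and lies within the scatter of both other compounds.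

Compound 4 `COc1cc(CN(CC2CC2)C(CC(=O)O)c2ccc(Cl)cc2)ccc1OCCn1c(=O)ccn(C)c1=O` differs from compound 3 in one place: methoxy in place of methyl on an aromatic carbon (methoxy in place of methyl on an aromatic carbon, ortho to a large group and meta to a large group).

Neither measured step touches that carbon. One is a 1.4-fold lower number from compound 1 to compound 3 (0.15 log units; within the scatter) on exchange of the ring-bearing group on the saturated chain, and the other is a 1.2-fold higher number from compound 2 to compound 3 (0.06 log units; within the scatter) with cyclopropyl in place of ethyl on a saturated chain carbon bound to an amine nitrogen. Both lie within the scatter. Within the data shown here, no measured pair tests methoxy against methyl, and the data offer no direct precedent for this change.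

The expectation starts from compound 3 at 3.7 nm/s and takes the size of its two steps as a guide. The step expected for compound 4 is a 1.1-fold lower number from compound 3 to compound 4 (0.04 log units; within the scatter) with no move beyond the scatter expected in either direction. The estimated value for compound 4 is 3.4 nm/s with 1.7 nm/s to 6.5 nm/s as the expected range.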

Compound 4, apparent permeability: 0.8 nm/s
Estimate against measurement, compound 4: 4.3-fold (0.63 log units) above, outside the stated range (below it).
By their numbers in this assay, from the lowest: compound 4; then compounds 2, 3 and 1 (each within the scatter of the next).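

The aromatic carbon ortho to a large group and meta to a large group is the one place in this set where a small exchange moves the number in this assay beyond the scatter: methoxy in place of methyl gives a 4.6-fold lower number from compound 3 to compound 4 (0.67 log units; beyond the scatter) on the shared core. The two earlier steps, a 1.4-fold lower number from compound 1 to compound 3 (0.15 log units; within the scatter) and a 1.2-fold higher number from compound 2 to compound 3 (0.06 log units; within the scatter), exchange much larger or comparable groups elsewhere and stay within the scatter, so this carbon carries a sensitivity in this assay that those compounds could not reveal. No accompanying measurement bears on what lies behind this step.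

The compounds shown leave open whether the step belongs to methoxy alone or extends to other groups on this carbon, such as ethoxy, a hydroxyl, a fluorine or a bare hydrogen. They also leave open whether the same exchange gives a step of like size with the other groups carried by compound 1 and compound 2.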